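From 4-chlorophenyl to 2,5-dimethoxyphenyl: one guiding step

The source may report more compounds than this note shows. Statements on the series, on what has been measured and on what is new or still open speak of the compounds shown alone.

compound 1 `O=C1/C(=C\c2ccc(Cl)cc2)S/C(=N/c2ccccc2)N1Cc1ccncc1` 42300 nM
compound 2 `O=C1/C(=C\c2ccc(O)c(O)c2)S/C(=N/c2ccccc2)N1Cc1ccncc1` 230000 nM

Among the compounds with values here, in an ADME assay on HEK293 cells (Homo sapiens) for cytotoxicity, read by MTT assay, with a stated time of 48 h (a lower number here means a stronger inhibitor, a higher number a weaker inhibitor), compound 1 gives 42300 nM as the lower of the two numbers so far. Compound 3 `COc1ccc(OC)c(/C=C2/S/C(=N/c3ccccc3)N(Cc3ccncc3)C2=O)c1` is still unmeasured and differs from compound 1 in one group, on a double-bonded chain carbon bound to a double-bonded ring carbon (2,5-dimethoxyphenyl in place of 4-chlorophenyl on a double-bonded chain carbon bound to a double-bonded ring carbon). Within the data shown here, the one measured step at that place (a 5.4-fold higher number from compound 1 to compound 2 (0.74 log units; beyond the scatter)) was modest and beyond the scatter, so a rise of similar or smaller size is expected in this assay for compound 3, though a single step is thin evidence. The estimated change is a 2.1-fold higher number from compound 1 to compound 3 (0.33 log units; beyond the scatter) overall. Compound 3 is estimated at 90000 nM (35000 nM to 230000 nM).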

Compound 3, half-maximal inhibitory concentration: 80100 nM
Estimate against measurement, compound 3: 1.1-fold (0.05 log units) above; the range from low to high includes it.
By their numbers in this assay, from the lowest: compounds 1 and 3 (each within the scatter of the next); then compound 2.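

In this assay, the step with 2,5-dimethoxyphenyl in place of 4-chlorophenyl is a 1.9-fold higher number from compound 1 to compound 3 (0.28 log units; within the scatter), so the two groups cannot be told apart here. The same group in place of 3,4-dihydroxyphenyl gives a 2.9-fold lower number from compound 2 to compound 3 (0.46 log units; beyond the scatter), so of the two oxygen-bearing groups, only 3,4-dihydroxyphenyl stands apart from 4-chlorophenyl. Nothing available explains this difference. Still open, as far as these compounds go, is how an amine or a carboxylic acid at this place would read in this assay, and how a phenyl ring carrying a single methoxy group would compare.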